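This account rests on a few compounds, and the source may have more. Where it says the series, first, only, none or still open, it means among the compounds named here.

In a functional assay on MGC-803 cells (Homo sapiens) for inhibition, read by MTT assay, with a stated time of 72 h (on this read-out higher numbers stand for weaker inhibition and lower numbers for stronger inhibition), compound 3 `C=CC(=O)Nc1cccc(NC(=O)CSc2nc(Nc3cccc(C)c3)c3ccccc3n2)c1` gives 20900 nM, the highest of the three numbers shown. Compound 1 `C=CC(=O)Nc1cccc(NC(=O)CSc2nc(Nc3ccccc3Cl)c3ccccc3n2)c1` gives 20700 nM, and the step of a 1.0-fold higher number from compound 1 to compound 3 (0.00 log units; within the scatter) lies within the scatter. Compound 2 `C=CC(=O)Nc1cccc(NC(=O)CSc2nc(Nc3cccc(F)c3)c3ccccc3n2)c1` gives 6250 nM, and the step of a 3.3-fold higher number from compound 2 to compound 3 (0.52 log units; beyond the scatter) lies beyond it. Compound 4 `C=CC(=O)Nc1cccc(NC(=O)CSc2nc(Nc3ccc(Cl)cc3)c3ccccc3n2)c1` differs from compound 3 in one place: 4-chlorophenyl in place of 3-methylphenyl on a nitrogen on an aromatic ring. For the measured compounds named here, no measured step exchanges a 3-methylphenyl for a 4-chlorophenyl. The step of a 1.0-fold higher number from compound 1 to compound 3 (0.00 log units; within the scatter) shows 2-chlorophenyl and 3-methylphenyl giving the same number, while a 3.3-fold lower number from compound 1 to compound 2 (0.52 log units; beyond the scatter) shows a modest lowering on going to 3-fluorophenyl. The step expected is a 1.7-fold lower number from compound 3 to compound 4 (0.24 log units; within the scatter), most likely no larger than modest and toward a lower number. The estimate for compound 4 in this assay is 12000 nM, with a range from 4000 nM to 35000 nM.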

Compound 4, half-maximal inhibitory concentration: 14300 nM
For compound 4 the middle estimate is 1.2-fold (0.08 log units) below the measured one, within the range that was stated.
By their numbers in this assay, from the lowest: compound 2; then compounds 4, 1 and 3 (each within the scatter of the next).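

In this assay, moving the chlorine on the phenyl ring changes little: the step of a 1.4-fold lower number from compound 1 to compound 4 (0.16 log units; within the scatter) stays within the scatter, so 2-chlorophenyl and 4-chlorophenyl cannot be told apart at this position. The step of a 1.5-fold lower number from compound 3 to compound 4 (0.16 log units; within the scatter) is also within the scatter, which places compound 4 level with both compound 1 and compound 3. Only the 3-fluorophenyl group stands apart, as the step of a 2.3-fold higher number from compound 2 to compound 4 (0.36 log units; beyond the scatter) lies beyond the scatter.

A 3-chlorophenyl or 4-fluorophenyl group could show whether the fluorine or its place on the ring sets compound 2 apart. Nothing available here explains that difference.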